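The source may hold more compounds than are shown below. What is called first, only, known or untested is meant among the compounds shown, and "the series" means these compounds.

Measured so far, in a functional assay on U-251 cells (Homo sapiens) for cytotoxicity, read by sulforhodamine B assay, with a stated time of 48 h, tested at 1 uM; a lower number here means a stronger effect, a higher number a weaker effect of the compound at the concentration tested:
- compound 1 `COc1cc(-c2cc(/C=C/C(=O)c3ccc(Cl)c(Cl)c3)[nH]n2)cc(OC)c1OC` gives 87%
- compound 2 `COc1ccc(C(=O)/C=C/c2cc(-c3cc(OC)c(OC)c(OC)c3)n[nH]2)cc1OC` gives 65%
- compound 3 `COc1ccc(C(=O)/C=C/c2cc(-c3cc(OC)c(OC)c(OC)c3)n[nH]2)cc1` gives 81%

Compound 3 stands second highest of the three numbers. Its nearest neighbour is compound 1, a step of a number 6 percentage points lower from compound 1 to compound 3 (within the scatter) that lies within the scatter, so the two cannot be ordered; its furthest is compound 2, where the step of a number 16 percentage points higher from compound 2 to compound 3 (beyond the scatter) is beyond the scatter, a modest gain.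

Compound 4 `COc1cc(-c2cc(/C=C/C(=O)c3ccc(F)c(F)c3)[nH]n2)cc(OC)c1OC` differs from compound 3 in one place: 3,4-difluorophenyl in place of 4-methoxyphenyl on a carbonyl carbon.

For the measured compounds named here, two measured steps bear on this change, both at the same carbonyl carbon. The step of a number 6 percentage points lower from compound 1 to compound 3 (within the scatter) shows that swapping a 3,4-dichlorophenyl for a 4-methoxyphenyl moves the number only within the scatter. The step of a number 22 percentage points lower from compound 1 to compound 2 (beyond the scatter) shows that a 3,4-dimethoxyphenyl in the same place loses a modest amount. Compound 4 carries a 3,4-difluorophenyl, a two-halogen pattern closer to that of compound 1 than to that of compound 2, so the expected step of a number 4 percentage points higher from compound 3 to compound 4 (within the scatter) from compound 3 is small, if anything slightly upward, and not beyond the scatter.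

Compound 4 is therefore estimated at 85%, with a range from 72% to 96%.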

Compound 4, a percentage reported as activity, at one concentration (the size of the read-out at that concentration, not a potency): 87%
Compound 4: the middle estimate sits 2 percentage points below what was measured; the measured number falls inside the stated range.
By their numbers in this assay, from the lowest: compound 2; then compounds 3, 1 and 4 (each within the scatter of the next).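

In this assay, the 3,4-difluorophenyl on the carbonyl carbon cannot be told apart from either group tried there before: the record shows no change at the digits printed from compound 1 to compound 4 (within the scatter), and a number 6 percentage points higher from compound 3 to compound 4 (within the scatter). The new group does separate from the 3,4-dimethoxyphenyl, with a number 22 percentage points higher from compound 2 to compound 4 (beyond the scatter), so compound 2 is now set apart from three compounds, and it goes against any reading that the group at this place makes no difference. Exchanging the two chlorines for two fluorines therefore leaves no visible mark on this read-out, and nothing available explains why compound 2 alone differs.

Going by these compounds, the rest of the core is the same in all four compounds, so the effect of changes elsewhere remains unknown, and a single tested concentration gives no potency for any of them. On these data alone, it also remains open how an amine or a carboxylic acid on this phenyl ring would compare, and whether such a group would move the number in the direction of compound 2 or leave it with the other three.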